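The source may hold more compounds than are shown below. What is called first, only, known or untested is meant among the compounds shown, and "the series" means these compounds.

In a functional assay on NB-4 cells (Homo sapiens) for cytotoxicity, read by CCK-8 assay, with a stated time of 24 h (on this read-out lower numbers stand for stronger inhibition and higher numbers for weaker inhibition), compound 1 `C=CC(=O)N1C(=O)CC(c2ccccc2Cl)Sc2ccccc21` gives 33800 nM. For the measured compounds named here, compound 2 `C=CC(=O)N1C(=O)CC(c2ccc([N+](=O)[O-])cc2)Sc2ccccc21` gives 37700 nM, and these two values lie within the usual scatter of each other, so compound 1 stands level with the only other compound measured. Compound 3 `C=CC(=O)N1C(=O)CC(c2ccc(C#N)cc2)Sc2ccccc21` is still to be measured. It departs from compound 1 in one place, on a saturated ring carbon next to the ring sulfur, with 4-cyanophenyl in place of 2-chlorophenyl (4-cyanophenyl in place of 2-chlorophenyl on a saturated ring carbon). Going by the values given here, no measured pair of compounds differing in one place is available to size such a change. Among the compounds with values here, the only guide is that compound 2, at 37700 nM, stays within the scatter of compound 1, so no step beyond the scatter is expected in this assay, in either direction. The expected change is a 1.0-fold higher number from compound 1 to compound 3 (0.02 log units; within the scatter). The estimated value for compound 3 is 35000 nM, with an expected range of 15000 nM to 80000 nM.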

Compound 3, half-maximal inhibitory concentration: 62400 nM
The estimate for compound 3 lay 1.8-fold (0.25 log units) below the measured number; measured number inside the range.
By their numbers in this assay, from the lowest: compounds 1, 2 and 3 (each within the scatter of the next).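

In this assay, for the compounds shown here, 4-cyanophenyl in place of 2-chlorophenyl on the saturated ring carbon next to the ring sulfur gives a 1.8-fold higher number from compound 1 to compound 3 (0.27 log units; within the scatter) and so produces no step that can be told from the scatter. Cyano in place of nitro on an aromatic carbon gives a 1.7-fold higher number from compound 2 to compound 3 (0.22 log units; within the scatter) and likewise stays unresolved, so the first two steps available at this position show that neither change separates the compounds in this assay. Nothing in the data gives a reason for this result.

The compounds shown leave open whether anything other than a substituted phenyl on this saturated ring carbon, such as a simple alkyl chain or a phenyl bearing an amine or a carboxylic acid, would give a step beyond the scatter. They also leave open how a saturated propanoyl group would read in place of the vinylcarbonyl group on the ring nitrogen.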